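The source may report more compounds than this note shows. Statements on the series, on what has been measured and on what is new or still open speak of the compounds shown alone.

Compound 1 `O=C1CC(c2nc(-c3ccc(F)cc3)no2)CN1c1ccc(Cl)c(Cl)c1` was examined in an in vitro functional assay on HEK293-A cells for positive allosteric modulation of metabotropic glutamate receptor 5 (Homo sapiens), read by FLIPR and calcium flux (a higher number here means that more compound is needed for the effect, a lower number that less compound is needed), where compound 1 gives 2300 nM. That is the highest of the two numbers recorded so far. The nearest is compound 2 `COc1cccc(-c2noc(C3CC(=O)N(c4ccc(F)cc4)C3)n2)c1`, which in this assay gives 1100 nM, a difference beyond the usual scatter of this kind of measurement. Compound 2 differs from compound 1 in more than one place, so nothing is known about how either change alone would shift the number.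

Going by the values given here, the next compound, compound 3 `O=C1CC(c2nc(-c3cccc(Cl)c3)no2)CN1c1ccc(Cl)c(Cl)c1`, keeps the core of compound 1 and changes only one group: 3-chlorophenyl in place of 4-fluorophenyl on an aromatic carbon. Among the compounds with values here, no measured pair isolates this change. On the evidence available, a small step in the this assay number is expected for compound 3, if anything towards a lower value, but one that may well fall within the scatter, so that the expected step is estimated as a 1.5-fold lower number from compound 1 to compound 3 (0.19 log units; within the scatter). Compound 3 is therefore estimated at 1500 nM, with a likely range from 600 nM to 4000 nM.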

Compound 3, half-maximal effective concentration: 460 nM
Estimate against measurement, compound 3: 3.3-fold (0.51 log units) above; measured number outside the range, below it.
By their numbers in this assay, from the lowest: compound 3; then compound 2; then compound 1.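

Going by these compounds alone, compound 1 and compound 3 form the first single-place pair in this assay, and they show that the number responds to the aryl group on this aromatic carbon, between two ring nitrogen atoms of the five-membered aromatic ring. With the rest of the core of compound 1 kept, 3-chlorophenyl in place of 4-fluorophenyl gives a step beyond the scatter (a 5.0-fold lower number from compound 1 to compound 3 (0.70 log units; beyond the scatter)), and compound 3 now has the lowest number of the three compounds. No measurement at hand explains this step.

The change alters both the halogen and its place on the phenyl ring, so the compounds shown leave open which of the two matters, a question that 4-chlorophenyl or 3-fluorophenyl at this position would address. Also open, on these data alone, is how a 3-methylphenyl or a pyridyl group would behave here.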